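The source may hold more compounds than are shown below. What is called first, only, known or untested is meant among the compounds shown, and "the series" means these compounds.

In a functional assay (Homo sapiens) for inhibition of Nucleic Acid, tested at 100 uM (a lower number here means less inhibition, a higher number more inhibition at the concentration tested (going by the name of the read-out)), the three measured compounds gave the following:

Compound 1, `[O-][n+]1ccc2[nH]cnc2c1`: 3%
Compound 2, `CN(C)c1nccc2c1ncn2C1O[C@H](CO)[C@@H](O)[C@H]1O`: 0%
Compound 3, `[O-][n+]1ccc2c(c1)ncn2C1O[C@H](CO)[C@@H](O)[C@H]1O`: 5%

All three numbers sit close to the floor of what this assay can report. Compound 2 gives the smallest figure of the three, but compound 1 and compound 3 lie within the usual scatter of it, so the three cannot be told apart; none of them shows meaningful inhibition at the concentration tested.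

Compound 4, `[N-]=[N+]=Nc1nccc2c1ncn2C1O[C@H](CO)[C@@H](O)[C@H]1O`, has not yet been measured. It differs from compound 2 in one place: azido in place of dimethylamino on an aromatic carbon. The shared core and the sugar are kept unchanged.

Among the compounds with values here, no step between measured compounds is available to guide the expectation, and the three measured numbers offer no trend to extend. Since compound 2 itself shows essentially no inhibition, the expected step of a number 3 percentage points higher from compound 2 to compound 4 (within the scatter) is none beyond the scatter. Compound 4 is therefore estimated to give 3%, with a plausible range from -5% to 12%.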

Compound 4, a percentage reported as inhibition, at one concentration (the size of the read-out at that concentration, not a potency): 4%
Compound 4: the middle estimate sits 1 percentage points below what was measured, and the stated range covers the measured number.
By their numbers in this assay, from the lowest: compounds 2, 1, 4 and 3 (each within the scatter of the next).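

In this assay, placing azido in place of dimethylamino on the aromatic carbon next to the ring nitrogen gives a number 4 percentage points higher from compound 2 to compound 4 (within the scatter) and so does not separate the two compounds. Within the data shown here, this is the first direct test of a single change at this position, which the earlier compounds could not provide, and this particular exchange leaves the reading unresolved from that of compound 2. No supporting data are available to interpret this result further.

Among these compounds, only two groups at this position can be compared here, so it remains open whether any other group on the same carbon would produce inhibition clearly beyond the scatter. A primary amine, a carboxylic acid or a longer chain in that place could test this, while the shared core and the sugar stay unchanged.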